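From Ethoxy to Hydroxy in Compound 4

This account rests on a few compounds, and the source may have more. Where it says the series, first, only, none or still open, it means among the compounds named here.

Measured in a functional assay on KB cells (Homo sapiens) for inhibition, read by sulforhodamine B assay, with a stated time of 72 h; a lower number here means a stronger inhibitor of growth, a higher number a weaker inhibitor of growth:
- Compound 1 `CCOC(=O)/C=C/c1ccncc1-c1ccc2[nH]ccc2c1`: > 10000 nM
- Compound 2 `CCOC(=O)/C=C/c1ccncc1-c1ccc2c(ccn2C)c1`: 6250 nM
- Compound 3 `COC(=O)/C=C/c1ccncc1-c1ccc2ccccc2c1`: 6730 nM

The value for compound 1 is a limit of the assay, not a number (the limit of > 10000 nM in this assay, at which 1 of the 3 values shown sits). Within the data shown here, compound 2 and compound 3 give the only two numbers, and they lie within the scatter of each other. Compound 4 `Cn1ccc2cc(-c3cnccc3/C=C/C(=O)O)ccc21` differs from compound 2 by hydrogen in place of ethyl on an oxygen next to a carbonyl group, which reads as ethoxycarbonyl to carboxy. Among the measured compounds shown here, the one measured step, an at least 1.6-fold lower number from compound 1 to compound 2 (0.20 log units; that floor lies within the scatter), is a methyl in place of hydrogen on an aromatic nitrogen, so no measured step covers this change. The expected step is a 2.2-fold higher number from compound 2 to compound 4 (0.35 log units; beyond the scatter), towards a higher number in this assay. For compound 4 the estimated value is 14000 nM, with an expected range of 5000 nM to 40000 nM.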

Compound 4, concentration for 50% growth inhibition: > 10000 nM
Compound 4: a limit, no number; the forecaster's own chance of this, stated with the estimate: 65%; the middle value does not contradict the limit.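

Among these compounds, compound 4 shows what happens at the ester itself, which the earlier compounds did not, since the one earlier step changed only the aromatic nitrogen: ethoxycarbonyl to carboxy gives an at least 1.6-fold higher number from compound 2 to compound 4 (0.20 log units; that floor lies within the scatter). In this assay compound 4 gives > 10000 nM, which is a limit of the assay and not a number. The carboxy compound therefore joins compound 1 at that limit, and the floor of the step cannot separate it from compound 2: the limit of > 10000 nM in this assay, at which 2 of the 4 values shown sit.

Going by these compounds, how far compound 4 lies past the limit stays open, so the full size of the step cannot be read. Also open, on these data alone, is how an amide or a longer alkoxy chain in place of ethoxy would read in this assay.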